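Replacing Pyridin-3-yl with Phenyl in Compound 1

A few compounds are considered here, and "the series" means these few. Any claim that something is new, unique, unknown or untested is made for them only; others in the source may bear on it.

Of the compounds shown here, three of a shared core have been measured in a functional assay on HCT-116 cells (Homo sapiens) for positive allosteric modulation, read by MTT assay, with stated times of 24 h and 48 h, tested at 2.5 uM; on this read-out lower numbers stand for less inhibition of growth and higher numbers for more inhibition of growth at the one concentration tested. Compound 1, `CS(=O)(=O)c1ccc(-c2cnc3[nH]cc(-c4nnc(-c5cccnc5)o4)c(=O)c3c2)cc1`, gives 28.6% in this assay. Compound 2, `N#Cc1ccc(-c2cnc3[nH]cc(-c4nnc(-c5ccc(Cl)cc5)o4)c(=O)c3c2)cc1`, gives 35.4% in this assay, and compound 3, `O=c1c(-c2nnc(-c3ccc(F)cc3)o2)c[nH]c2ncc(-c3ccncc3)cc12`, gives 19.6% in this assay. The gap from compound 1 to compound 2 and the gap from compound 1 to compound 3 both lie within the usual scatter of this kind of measurement, so the three numbers cannot be told apart with confidence, and no single-point change between any two measured compounds has been worked out.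

Compound 4, `CS(=O)(=O)c1ccc(-c2cnc3[nH]cc(-c4nnc(-c5ccccc5)o4)c(=O)c3c2)cc1`, differs from compound 1 in one place: phenyl in place of pyridin-3-yl on an aromatic carbon. The group that enters sits on the same aromatic carbon of the five-membered ring, next to the ring nitrogen and the ring oxygen, as the group that leaves.

Within the data shown here, with no measured step to lean on, and the three measured numbers all within the scatter of one another, no shift beyond the scatter is expected in this assay for this change. Compound 4 is expected to give about 27%, between 15% and 40%, which means an estimated step of a number 1.6 percentage points lower from compound 1 to compound 4 (within the scatter) that stays within the scatter.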

Compound 4, percent growth inhibition at one concentration: 27.2%
The estimate for compound 4 lay 0.2 percentage points below the measured number; the measured number falls inside the stated range.
By their numbers in this assay, from the lowest: compounds 3, 4, 1 and 2 (each within the scatter of the next, the first and the last beyond it).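

In this assay, among these compounds, phenyl in place of pyridin-3-yl on the aromatic carbon of the five-membered ring gives a number 1.4 percentage points lower from compound 1 to compound 4 (within the scatter), the first step at this position that can be read between compounds differing in one place. With the rest of compound 1 held fixed, exchanging the ring nitrogen of pyridin-3-yl for carbon, and so going from a group with a hydrogen-bond acceptor to one without, therefore leaves the read-out within the scatter at the one concentration tested, and compound 1 and compound 4 cannot be told apart. No measurement at hand speaks to why this exchange makes no larger difference.

The compounds shown carry only six-membered aromatic rings on this carbon, so it stays open whether an amine, a carboxylic acid or a longer alkyl chain there would give a step beyond the scatter. Going by these compounds, it also stays open whether pyridin-2-yl or pyridin-4-yl on this carbon, with the rest of compound 1 unchanged, would read like pyridin-3-yl and phenyl.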